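The compounds below may be only part of what the source reports. "The series", "measured", "known", "first", "only" and "open" are said of these compounds alone.

Compound 1 `COc1ccc(-c2nnc(-c3cc(OC(F)(F)F)ccc3N3CCCCC3)o2)cc1OC`: 5860 nM
Compound 2 `COc1ccc(-c2nnc(-c3cc(OC(F)(F)F)ccc3N3CCCC3)o2)cc1OC`: > 30000 nM

In a functional assay on cells for negative allosteric modulation of metabotropic glutamate receptor 7 (Rattus norvegicus), read by fluorescence and calcium flux, with stated times of 142 s, 120 s and 40 s (on this read-out higher numbers stand for weaker inhibition and lower numbers for stronger inhibition), compound 1 gives 5860 nM. Compound 2 reaches only the limit of this assay, > 30000 nM, so no number stands for it. Within the data shown here, the one measured step, an at least 5.1-fold higher number from compound 1 to compound 2 (0.70 log units; beyond the scatter), is bounded by the limit of > 30000 nM in this assay, at which 1 of the 2 values shown sits. Compound 3 `COc1ccc(-c2nnc(-c3cc(OC(F)(F)F)ccc3N3CCN(C)CC3)o2)cc1OC` carries the change (4-methylpiperazin-1-yl in place of pyrrolidin-1-yl on an aromatic carbon), which again brings a six-membered non-aromatic ring in place of the five-membered one of compound 2, as compound 1 has. Among the measured compounds shown here, since the only step with a number runs from the six-membered to the five-membered ring and weakened inhibition beyond the scatter, the return to a six-membered ring is expected to move the number in the other direction, though the added hetero atom has no measured counterpart here. Compound 3 is therefore expected to give 15000 nM, in the range 4000 nM to 40000 nM, an expected step of an at least 2.0-fold lower number from compound 2 to compound 3 (0.30 log units; that floor lies within the scatter).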

Compound 3, half-maximal inhibitory concentration: > 30000 nM
Compound 3 was reported as a limit; the forecaster's own chance of this, stated with the estimate: 45%; middle value at least 2.0-fold (0.30 log units) from the limit.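

Compound 1 and compound 3 both carry a six-membered non-aromatic ring on the aromatic carbon para to a trifluoromethoxy group, yet 4-methylpiperazin-1-yl in place of piperidin-1-yl gives an at least 5.1-fold higher number from compound 1 to compound 3 (0.70 log units; beyond the scatter) in this assay. A six-membered ring at this position is thus not enough to keep the inhibition seen with compound 1, and among the compounds shown, only piperidin-1-yl gives a number rather than a limit. The step between compound 2 and compound 3 cannot be read, and the series now rests largely on a limit: the limit of > 30000 nM in this assay, at which 2 of the 3 values shown sit.

From the compounds shown here alone, it remains open whether the second ring nitrogen or its methyl group accounts for the step, which piperazin-1-yl without the methyl or 4-methylpiperidin-1-yl could separate. Also open, going by these compounds, is whether morpholin-4-yl, azepan-1-yl or an open-chain dimethylamino group would give a lower number than compound 1.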